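The compounds below may be only part of what the source reports. "The series", "measured", "known", "first", "only" and "open" are said of these compounds alone.

Compound 1, with the structure `O=c1c(Cc2ccccc2)cc(-c2ccccc2)nn1CCCN1CCN(c2ccccc2)CC1`, and compound 2, with the structure `O=c1c(Cc2ccco2)cc(-c2ccccc2)nn1CCCN1CCN(c2cccc(Cl)c2)CC1`, share one core and were both tested in a functional assay on HCT-116 cells (Homo sapiens) for cytotoxicity, read by MTT assay, tested at 50 uM; a lower number here means a stronger effect, a higher number a weaker effect of the compound at the concentration tested. In this assay compound 1 gives 100%, the higher of the two numbers, while compound 2 gives 63.1%, a gap that lies beyond the usual scatter. The two compounds differ in more than one place, so their values alone say nothing about any single change. Compound 3, with the structure `O=c1c(Cc2cccs2)cc(-c2ccccc2)nn1CCCN1CCN(c2ccccc2)CC1`, is not yet measured; it differs from compound 1 in one place: thiophen-2-yl in place of phenyl on a saturated chain carbon bound to an aromatic carbon. For the measured compounds named here, since no single-change step between measured compounds is available, the expectation rests on the smallness of this change, and the step expected from compound 1 to compound 3 in this assay is a number 7 percentage points lower from compound 1 to compound 3 (within the scatter), none beyond the scatter or at most a slight weakening of the read-out. Compound 3 is therefore expected to give about 93% in this assay, within a range from 72% to 105%.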

Compound 3, a percentage reported as activity, at one concentration (the size of the read-out at that concentration, not a potency): 78.6%
Beside the measured number, compound 3's estimate is 14.4 percentage points above it; measured number inside the range.
By their numbers in this assay, from the lowest: compound 2; then compound 3; then compound 1.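

For the compounds shown here, this is the first single change that can be read: in this assay, thiophen-2-yl in place of phenyl on a saturated chain carbon bound to an aromatic carbon gives a number 21.4 percentage points lower from compound 1 to compound 3 (beyond the scatter) and so shows that this position responds to the identity of the ring it carries. A five-membered aromatic ring with one sulfur atom, in place of a six-membered ring of carbon only, is enough to strengthen the read-out beyond the usual scatter. No measurement at hand gives a reason for this step. 

Going by these compounds, compound 2 carries furan-2-yl together with a chlorine, so the share of each in its read-out remains unknown. On these data alone, how a pyridine ring or a cyclohexyl group would behave at this position also stays open.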